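A Change on the Ring Nitrogen of Compound 1

The source may hold more compounds than are shown below. What is called first, only, known or untested is meant among the compounds shown, and "the series" means these compounds.

Compound 1 `CCCn1c(=O)[nH]c2nc(-c3ccc(S(=O)(=O)N4CCN(c5ccccc5Br)CC4)cc3)[nH]c2c1=O` and compound 2 `CCCn1c(=O)c2[nH]c(-c3ccc(S(=O)(=O)N4CCN(c5ccc(Cl)cc5)CC4)cc3)nc2n(C)c1=O` share the same core and were both tested in an assay on CHO cells for displacement of a labelled ligand from adenosine receptor A1 (Homo sapiens), read by scintillation counting, with a stated time of 90 min, tested at 1 uM, in the presence of a further agent that is not named here; a higher number here means more inhibition at the concentration tested (going by the name of the read-out), a lower number less inhibition. In this assay compound 1 gives 28%, and compound 2 gives 22%. These two readings lie within the usual scatter of repeated measurements, so nothing on the numbers shown sets compound 1 apart from compound 2. Compound 3 `CCCn1c(=O)[nH]c2nc(-c3ccc(S(=O)(=O)N4CCN(C(C)c5ccccc5)CC4)cc3)[nH]c2c1=O` has not yet been measured. It differs from compound 1 in one place: 1-phenylethyl in place of 2-bromophenyl on an amine nitrogen in a ring. Among the measured compounds shown here, no measured pair shows what such a change does, so there is no basis for expecting a step beyond the scatter in either direction. Compound 3 is therefore expected to give about 26% in this assay, with a likely range from 5% to 50%, which is an estimated step of a number 2 percentage points lower from compound 1 to compound 3 (within the scatter).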

Compound 3, a percentage reported as inhibition, at one concentration (the size of the read-out at that concentration, not a potency): 42%
Compound 3: middle estimate off by 16 percentage points, on the low side; measured number inside the range.
By their numbers in this assay, from the lowest: compounds 2 and 1 (each within the scatter of the next); then compound 3.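

Among the compounds shown here, this position on the amine nitrogen in the ring responds to a change of group: in this assay, 1-phenylethyl in place of 2-bromophenyl gives a number 14 percentage points higher from compound 1 to compound 3 (beyond the scatter) and provides the first comparison here of compounds that differ in one place. Both groups carry a six-membered aromatic ring of carbon only and neither has hydrogen-bond donors or acceptors, so the step comes without any change in those counts. No measurement here explains the step.

This single pair cannot show whether losing the bromine or gaining the extra carbons in 1-phenylethyl matters more. Going by these compounds, a plain benzyl group would help to separate the two, while the effect of a carboxylic acid or an amine on the phenyl ring of 1-phenylethyl remains open.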